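Replacing the aryl group on the amine nitrogen with cyclohexyl

The compounds below may be only part of what the source reports. "The series", "measured", "known", "first", "only" and "open" are said of these compounds alone.

Compound 1 `O=C1C(Nc2ccc(I)cc2)=CC(=O)c2c1nc1n2[C@H]2OC[C@@H](O)[C@H]2OC1`: 4010 nM
Compound 2 `O=C1C(Nc2ccc(C(F)(F)F)cc2)=CC(=O)c2c1nc1n2[C@H]2OC[C@@H](O)[C@H]2OC1`: 8920 nM
Compound 3 `O=C1C(NC2CCCCC2)=CC(=O)c2c1nc1n2[C@H]2OC[C@@H](O)[C@H]2OC1`: not yet measured

In a functional assay on HeLa cells (Homo sapiens) for inhibition, read by sulforhodamine B assay (a higher number here means a weaker inhibitor, a lower number a stronger inhibitor), compound 2 stands higher of the two measured compounds at 8920 nM. Compound 3 differs from it on an amine nitrogen: cyclohexyl in place of 4-(trifluoromethyl)phenyl on an amine nitrogen. Among the measured compounds shown here, only one measured step bears on this, a 2.2-fold higher number from compound 1 to compound 2 (0.35 log units; beyond the scatter), a modest change on an aromatic carbon, and no measured compound carries a non-aromatic ring on that nitrogen. With so little to go on, no step beyond the scatter is expected in this assay, although a modest one in either direction remains possible. The estimated step is a 1.0-fold higher number from compound 2 to compound 3 (0.00 log units; within the scatter). For compound 3, the expected value is 9000 nM, with an estimated range of 3000 nM to 25000 nM.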

Compound 3, half-maximal inhibitory concentration: > 16000 nM
Compound 3 was reported as a limit (the forecaster's own chance of this, stated with the estimate: 10%); middle value at least 1.7-fold (0.24 log units) away from the limit.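

In this assay compound 3 is reported only as a limit, > 16000 nM. Cyclohexyl in place of 4-iodophenyl on the amine nitrogen gives an at least 3.9-fold higher number from compound 1 to compound 3 (0.60 log units; beyond the scatter), while cyclohexyl in place of 4-(trifluoromethyl)phenyl gives an at least 1.7-fold higher number from compound 2 to compound 3 (0.25 log units; that floor lies within the scatter). The earlier step changed only a group on the aromatic ring, whereas this result shows that a non-aromatic ring on this nitrogen gave no stronger inhibitor than either aryl group.

From the compounds shown here alone, how far compound 3 lies beyond its limit remains unknown. Going by these compounds, whether a benzyl group or a straight alkyl chain on that nitrogen would behave like cyclohexyl also remains open.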